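Chloro for Methoxy on a Chromone Acid Series

A few compounds are considered here, and "the series" means these few. Any claim that something is new, unique, unknown or untested is made for them only; others in the source may bear on it.

Measured so far:
compound 1, `O=C(O)c1ccc2oc(-c3ccc(Cl)cc3)c(O)c(=O)c2c1`, -19%
compound 2, `COc1c(-c2ccc(C(C)C)cc2)oc2ccc(C(=O)O)cc2c1=O`, 18%
compound 3, `COc1ccc(-c2oc3ccc(C(=O)O)cc3c(=O)c2OC)cc1`, 22%

In a functional assay on the whole organism (stomach) for inhibition, with Rattus norvegicus as the target, at a dose of 80 mg/kg (a lower number here means less inhibition, a higher number more inhibition at the dose given (going by the name of the read-out)), compound 3 gives 22%, the highest of the three numbers recorded. Its nearest neighbour is compound 2, whose value of 18% lies within the scatter of compound 3, so the two cannot be ordered. Compound 1, with -19%, sits far below both and beyond the scatter.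

Compound 4, `COc1c(-c2ccc(Cl)cc2)oc2ccc(C(=O)O)cc2c1=O`, is the next compound in line. It differs from compound 3 in one place: chloro in place of methoxy on an aromatic carbon.

For the measured compounds named here, only one measured step bears on this change, and only loosely. The step of a number 4 percentage points higher from compound 2 to compound 3 (within the scatter) shows that swapping one group for another on the same aromatic carbon left this assay essentially unchanged. Compound 1 also carries a chloro at that position, yet it differs from compound 4 in a second place as well, so its low value can only hint that the number in this assay may come out lower here. Taking both observations together, a modest downward movement is expected, with considerable uncertainty.

Compound 4 is therefore estimated at 10%, in the range -15% to 30%, which would mean an expected step of a number 12 percentage points lower from compound 3 to compound 4 (beyond the scatter).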

Compound 4, a percentage reported as inhibition, in the whole organism at one dose (the size of the read-out at that dose, not a potency): 34%
For compound 4 the middle estimate is 24 percentage points below the measured one; the whole stated range lies below it.
By their numbers in this assay, from the lowest: compound 1; then compounds 2 and 3 (each within the scatter of the next); then compound 4.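

At this aromatic carbon, the earlier pair had left isopropyl and methoxy inseparable in this assay, but chloro stands apart from both, with a number 12 percentage points higher from compound 3 to compound 4 (beyond the scatter) and with a number 16 percentage points higher from compound 2 to compound 4 (beyond the scatter) in the same direction. The largest change lies at the other varied place, where methyl in place of hydrogen on the oxygen gives a number 53 percentage points higher from compound 1 to compound 4 (beyond the scatter) and turns the negative number of compound 1 into the highest of the four. Compound 1 therefore shows a chloro compound with a free hydroxyl at that oxygen and says little about chloro alongside the methoxy group, which is the pairing in compound 4. Nothing measured here explains why chloro separates from the other two groups.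

The compounds shown leave open whether the rise belongs to chloro alone or would also appear with fluoro, bromo or an amine on the same aromatic carbon. They also leave open whether a longer chain, such as ethyl, on the oxygen would carry the gain over hydrogen further than methyl does.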